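A Chloro Substituent Enters the Shared Core

The source may hold more compounds than are shown below. What is called first, only, known or untested is meant among the compounds shown, and "the series" means these compounds.

Three analogues on a shared core have been measured in an ADME assay on HepG2 cells (Homo sapiens) for inhibition, read by fluorescence and resazurin assay, with a stated time of 72 h; a higher number here means a weaker inhibitor, a lower number a stronger inhibitor. Compound 1 `NS(=O)(=O)c1cccc(Nc2nccc(Nc3ccc4nc[nH]c4c3)n2)c1` returns only a limit of the assay, > 25000 nM. Compound 2 `CS(=O)(=O)Nc1cccc(Nc2nccc(Nc3ccc4nc[nH]c4c3)n2)c1` likewise returns only a limit, > 25000 nM. Among the measured compounds shown here, compound 3 `Cc1cccc(Nc2nccc(Nc3ccc4nc[nH]c4c3)n2)c1` is the one compound with a number, giving 20000 nM in this assay. The steps of an at least 1.2-fold lower number from compound 1 to compound 3 (0.09 log units; that floor lies within the scatter) and an at least 1.2-fold lower number from compound 2 to compound 3 (0.09 log units; that floor lies within the scatter) are floors only, because of the limit of > 25000 nM in this assay, at which 2 of the 3 values shown sit, and both lie within the scatter. Compound 4 `Cc1cccc(Nc2ncc(Cl)c(Nc3ccc4nc[nH]c4c3)n2)c1` differs from compound 3 by chloro in place of hydrogen on an aromatic carbon. For the measured compounds named here, no measured step touches this place; all three measured steps alter a different group. The expectation is therefore no step beyond the scatter, a 1.4-fold lower number from compound 3 to compound 4 (0.15 log units; within the scatter). For compound 4 the estimate is 14000 nM, between 4000 nM and 40000 nM.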

Compound 4, half-maximal inhibitory concentration: 7400 nM
Compound 4: the middle estimate sits 1.9-fold (0.28 log units) above what was measured; measured number inside the range.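

In this assay, chloro in place of hydrogen on an aromatic carbon, para to a (3-methylphenyl)amino group, gives a 2.7-fold lower number from compound 3 to compound 4 (0.43 log units; beyond the scatter), the only step shown with a number at both ends. Among the compounds shown here, this position, which no earlier step touched, thus responds to a change, whereas the earlier steps gave only floors within the scatter. Nothing shown gives a reason for this step. From the compounds shown here alone, whether bromo or an amine at this position would move the number further remains open. So does whether chloro gives a similar step alongside sulfamoyl or methanesulfonamido.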